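Shortening and Branching the Chain of Compound 2

The source may hold more compounds than are shown below. What is called first, only, known or untested is meant among the compounds shown, and "the series" means these compounds.

Two measured compounds share one core and differ only in the saturated chain attached to the nitrogen on the aromatic ring. Compound 1 `CCCCNc1ccc(C(=O)O)cc1S(=O)(=O)NC` carries the shorter chain; in an assay on HEK293 cells for inhibition of solute carrier family 12 member 2 (Homo sapiens), read by fluorescence, with a stated time of 30 min, tested at 100 uM (a lower number here means a weaker effect, a higher number a stronger effect of the compound at the concentration tested), compound 1 gives 6.2%. Compound 2 `CCCCCCCCNc1ccc(C(=O)O)cc1S(=O)(=O)NC` carries the longer chain, and in this assay compound 2 gives 20.1%, the higher of the two numbers. Among the measured compounds shown here, the single step measured so far, a number 13.9 percentage points higher from compound 1 to compound 2 (beyond the scatter), shows the longer chain going with the stronger read-out.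

Compound 3 `CNS(=O)(=O)c1cc(C(=O)O)ccc1NCCC(C)(C)C` has not yet been measured. It differs from compound 2 by tert-butyl in place of hexyl on a saturated chain carbon, two bonds along the chain from a nitrogen on an aromatic ring. The chain thus becomes shorter and branched. For the measured compounds named here, only one measured step bears on this, a number 13.9 percentage points higher from compound 1 to compound 2 (beyond the scatter), and it points in the opposite direction to shortening. A fall is therefore expected, although how the branching weighs is not known from these two compounds. The expected step is a number 8.1 percentage points lower from compound 2 to compound 3 (within the scatter), a modest drop that should leave compound 3 between its two neighbours. Compound 3 is estimated to give 12% in this assay, with a likely range from 2% to 25%.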

Compound 3, a percentage reported as inhibition, at one concentration (the size of the read-out at that concentration, not a potency): 2.6%
Compound 3: the middle estimate sits 9.4 percentage points above what was measured; measured number inside the range.
By their numbers in this assay, from the lowest: compounds 3 and 1 (each within the scatter of the next); then compound 2.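

In this assay, tert-butyl in place of hexyl at this place on the chain gives a number 17.5 percentage points lower from compound 2 to compound 3 (beyond the scatter), so the higher read-out of compound 2 does not survive this change. Tert-butyl in place of ethyl at the same place gives a number 3.6 percentage points lower from compound 1 to compound 3 (within the scatter), which means that the branched chain of compound 3 and the straight butyl chain of compound 1 cannot be told apart here, and the branched end brings no gain over the short straight chain. No measurement shown here accounts for this behaviour of the chain.

Chain length and branching change together in the step to compound 3, so the compounds shown leave open how much of the loss belongs to each of them. A straight hexyl chain on the same nitrogen, set against the chain of compound 3, would separate the two, and a decyl chain would show whether the read-out goes on climbing beyond that of compound 2.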